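Moving the Thiophene Attachment Point on a Second Core

The source may report more compounds than this note shows. Statements on the series, on what has been measured and on what is new or still open speak of the compounds shown alone.

In an assay on membranes from HEK293 cells for displacement of a labelled ligand from adenosine receptor A2b (Homo sapiens), read by scintillation counting, with a stated time of 30 min, tested at 1 uM (on this read-out higher numbers stand for more inhibition at the one concentration tested (going by the name of the read-out) and lower numbers for less inhibition), compound 1 `CC1=C(C(=O)OCC(C)C)C(c2cccs2)NC(=O)N1C` gives 2%. Compound 2 `CC1=C(C(=O)OCC(C)C)C(c2ccsc2)NC(=O)N1C` carries thiophen-3-yl in place of thiophen-2-yl on a saturated ring carbon, and in this assay compound 2 gives 1%, a step of a number 1 percentage points lower from compound 1 to compound 2 (within the scatter). Compound 3 `CCSC(=O)C1=C(C)NC(=O)NC1c1cccs1` rests on a different core; the difference between the two cores is not broken down here. In this assay compound 3 gives 1%, level with compound 2 at the digits reported. Compound 4 `CCSC(=O)C1=C(C)NC(=O)NC1c1ccsc1` is reached from compound 3 by the same kind of change, (thiophen-3-yl in place of thiophen-2-yl on a saturated ring carbon); the surroundings differ in that the new group sits next to the ring atom that bears a (ethylsulfanyl)carbonyl group rather than an isobutoxycarbonyl group. The step from compound 3 to compound 4 is expected to be no change at the digits printed from compound 3 to compound 4 (within the scatter), because a number 1 percentage points lower from compound 1 to compound 2 (within the scatter) stayed within the scatter. Compound 4 is therefore estimated at 1%, between 0% and 8%.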

Compound 4, a percentage reported as inhibition, at one concentration (the size of the read-out at that concentration, not a potency): 17%
Compound 4: the middle estimate sits 16 percentage points below what was measured; measured number above the stated range.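

On the core that carries the (ethylsulfanyl)carbonyl group, thiophen-3-yl in place of thiophen-2-yl gives a number 16 percentage points higher from compound 3 to compound 4 (beyond the scatter) in this assay as a percentage at one concentration, not a potency. The effect of this change therefore does not carry over unchanged between these two cores: the same change on two cores in this assay, a number 1 percentage points lower (within the scatter) from compound 1 to compound 2 and a number 16 percentage points higher (beyond the scatter) from compound 3 to compound 4, 17 percentage points apart, beyond the scatter of two such steps. These two pairs do not show why the cores differ, or how the change would behave on any further core.

The compounds shown leave open whether a phenyl ring on the saturated ring carbon would follow thiophen-3-yl or thiophen-2-yl. They also leave open whether a longer chain in place of the ethyl on the sulfur would keep the step.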